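The source may hold more compounds than are shown below. What is called first, only, known or untested is meant among the compounds shown, and "the series" means these compounds.

Measured so far in a functional assay on the whole organism for agonist activity, with Mus musculus as the target (on this read-out lower numbers stand for an effect already at smaller amounts and higher numbers for an effect only at larger amounts of compound), for this series:
compound 1 `CC(=O)N(C)C(C)C#CCn1ccnc1` gives 3 mg/kg
compound 2 `COC(=O)N(C)CC#CCn1ccnc1` gives 4.5 mg/kg
compound 3 `COC(=O)N(C)C(C)C#CCN1CCCC1` gives 20.9 mg/kg

Compound 3 at 20.9 mg/kg has the highest of the three numbers. It lies beyond the scatter from both compound 1 and compound 2, whose own values are within the scatter of each other.

The next compound to be read is compound 4 `COC(=O)N(C)C(C)C#CCn1ccnc1`, which has 1H-imidazol-1-yl in place of pyrrolidin-1-yl on a saturated chain carbon bound to a triple-bonded carbon. Going by the values given here, no measured pair isolates this change, so the evidence is indirect. The two compounds that carry 1H-imidazol-1-yl both have lower numbers than compound 3 in this assay: compound 1 stands at 3 mg/kg and compound 2 at 4.5 mg/kg, and neither goes against this three-compound pattern. Both also differ from compound 4 elsewhere in the structure, which limits the inference.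

A step beyond the scatter toward a lower number is therefore expected, with the estimated step being a 5.2-fold lower number from compound 3 to compound 4 (0.72 log units; beyond the scatter) in size. For compound 4 the estimated value is 4 mg/kg, and a range of 1.5 mg/kg to 10 mg/kg is expected.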

Compound 4, dose for half-maximal effect: 8 mg/kg
Beside the measured number, compound 4's estimate is 2.0-fold (0.30 log units) below it, within the range that was stated.
By their numbers in this assay, from the lowest: compounds 1, 2 and 4 (each within the scatter of the next, the first and the last beyond it); then compound 3.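

Read in this assay, the exchange of pyrrolidin-1-yl for 1H-imidazol-1-yl on a saturated chain carbon bound to a triple-bonded carbon is now isolated in a single pair, and it gives a 2.6-fold lower number from compound 3 to compound 4 (0.42 log units; beyond the scatter), a modest step that the earlier compounds could only suggest indirectly. The two other single changes can now be read as well: methyl in place of hydrogen on a saturated chain carbon bound to an amide-type nitrogen and a triple-bonded carbon gives a 1.8-fold higher number from compound 2 to compound 4 (0.25 log units; within the scatter), which cannot be told from the scatter, while methoxy in place of methyl on a carbonyl carbon gives a 2.7-fold higher number from compound 1 to compound 4 (0.43 log units; beyond the scatter), again modest. No measurement at hand explains any of these steps.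

As far as these compounds go, it remains open whether the step between the two rings holds when the carbonyl carbon bears methyl or when the chain carbon bears hydrogen, since each ring has been compared in only one such setting. Also open, from the compounds shown here alone, is how a piperidin-1-yl ring or a dimethylamino group would read in place of these rings, and how an ethyl group would read in place of the methyl on the chain carbon.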